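Cytotoxicity notes: aryl amide swap in the arylidene succinimide series

The source may hold more compounds than are shown below. What is called first, only, known or untested is meant among the compounds shown, and "the series" means these compounds.

Compound 1 `COc1ccc(NC(=O)c2cccc(/C=C3\CC(=O)N(c4ccccc4)C3=O)c2)c(C)c1` is benchmarked in an ADME assay on HCT-116 cells (Homo sapiens) for cytotoxicity, read by MTT assay, with a stated time of 72 h; a higher number here means a weaker inhibitor, a lower number a stronger inhibitor. In this assay compound 1 gives only a limit, > 100000 nM, with no number behind it; this is the limit of > 100000 nM in this assay, at which 1 of the 2 values shown sits. Compound 2 `CCCCNC(=O)c1cccc(/C=C2\CC(=O)N(Cc3ccccc3)C2=O)c1` gives 95100 nM in this assay. Compound 3 `O=C(Nc1ccc(Cl)cc1)c1cccc(/C=C2\CC(=O)N(c3ccccc3)C2=O)c1` carries 4-chlorophenyl in place of 4-methoxy-2-methylphenyl on an amide-type nitrogen. Among the compounds with values here, no measured step is available for this change, so the expected step from compound 1 to compound 3, a number no higher from compound 1 to compound 3 (the limit leaves the size open), is none beyond the scatter, with compound 1 already at the limit. Compound 3 is therefore expected at 100000 nM, with a range of 40000 nM to 250000 nM in this assay.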

Compound 3, half-maximal inhibitory concentration: > 100000 nM
Compound 3: a limit, no number; the forecaster's own chance of this, stated with the estimate: 60%; the middle value sits exactly at the limit.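

Compound 1 and compound 3 both give only a limit in this assay, so no step can be read between them: the limit of > 100000 nM in this assay, at which 2 of the 3 values shown sit. Going by these compounds, whether 4-chlorophenyl in place of 4-methoxy-2-methylphenyl changes cytotoxicity at all remains open.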